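Methyl added to the sulfur compound of the series

The compounds below may be only part of what the source reports. "The series", "measured", "known", "first", "only" and "open" are said of these compounds alone.

compound 1 `COc1cc(-c2cc(=O)[nH]c3c(O)c(OC)ccc23)cc([Se]C)c1OC`: 51.7 nM
compound 2 `COc1cc(-c2cc(=O)[nH]c3c(O)c(OC)ccc23)cc(SC)c1OC`: 35.5 nM

In a functional assay on HeLa cells (Homo sapiens) for inhibition, read by MTT assay, with a stated time of 48 h (a lower number here means a stronger inhibitor, a higher number a weaker inhibitor), compound 2 gives 35.5 nM, which lies within the scatter of compound 1 at 51.7 nM, so the two cannot be ranked. Compound 3 `COc1cc(-c2c(C)c(=O)[nH]c3c(O)c(OC)ccc23)cc(SC)c1OC` has not been measured and differs from compound 2 by one change: methyl in place of hydrogen on an aromatic carbon. This places a methyl on an aromatic carbon of the six-membered aromatic ring with 1 nitrogen.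

Within the data shown here, the only measured step, a 1.5-fold lower number from compound 1 to compound 2 (0.16 log units; within the scatter), swaps a selenium-containing group for a sulfur-containing one. Among the measured compounds shown here, it says nothing directly about a methyl in place of hydrogen, and no measured compound varies this site. For the measured compounds named here, it shows only that one single-site change in this pair stayed within the scatter. The direction of the new step is therefore open, with a slight lean towards a higher number and a wide margin on both sides. The expected step is a 1.5-fold higher number from compound 2 to compound 3 (0.19 log units; within the scatter), which would not clearly exceed the scatter. The estimate for compound 3 is 55 nM, with an expected range of 12 nM to 220 nM.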

Compound 3, half-maximal inhibitory concentration: 158 nM
Estimate against measurement, compound 3: 2.9-fold (0.46 log units) below; the measured number falls inside the stated range.
By their numbers in this assay, from the lowest: compounds 2 and 1 (each within the scatter of the next); then compound 3.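

In this assay, among these compounds, methyl in place of hydrogen on an aromatic carbon of the six-membered aromatic ring with 1 nitrogen gives a 4.5-fold higher number from compound 2 to compound 3 (0.65 log units; beyond the scatter), the only step so far that lies beyond the scatter. This position is therefore not indifferent to substitution: a single added methyl is enough to move the number clearly, whereas the exchange of the selenium-containing group for the sulfur-containing one, at another site of the shared core, stayed within the scatter. No available measurement bears on what lies behind this loss of inhibition.

The compounds shown hold only hydrogen and methyl at this carbon, so it remains open whether the higher number is particular to methyl or would also follow from another group here, such as a chlorine atom, an amine, a carboxylic acid or a longer chain like ethyl. Among the compounds shown here, also open is whether the step would carry over to the selenium-containing compound 1, since the methyl step is seen only on the sulfur-containing compound 2.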